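This account rests on a few compounds, and the source may have more. Where it says the series, first, only, none or still open, it means among the compounds named here.

Measured so far:
- compound 1 `CCc1cc(-c2noc(-c3cc(C)cc(CN(C)CC)c3)n2)cc(C)c1OC[C@@H](O)CNC(=O)CO` gives 3.4 in a physicochemical assay for lipophilicity, in phosphate buffer, at pH 7; on this read-out lower numbers stand for lower lipophilicity and higher numbers for higher lipophilicity.
- compound 2 `CCCCN(C)Cc1cc(C)cc(-c2nc(-c3cc(C)c(OC[C@@H](O)CNC(=O)CO)c(CC)c3)no2)c1` gives > 4.1; this is a limit of the assay, not a number.
- compound 3 `CCc1cc(-c2noc(-c3cc(C)cc(CN(C)CC(C)C)c3)n2)cc(C)c1OC[C@@H](O)CNC(=O)CO` gives > 4.1; this too is a limit, not a number.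

Within the data shown here, compound 1 thus holds the only true number among the three, the other two sitting at the limit of > 4.1 in this assay, at which 2 of the 3 values shown sit. The steps of a number at least 0.70 log units higher from compound 1 to compound 2 (beyond the scatter) and a number at least 0.70 log units higher from compound 1 to compound 3 (beyond the scatter) both added carbon to the chain on the amine nitrogen, while a step that the two limits leave unreadable from compound 2 to compound 3 cannot be read.

Compound 4 `CCc1cc(-c2noc(-c3cc(C)c(CN(C)C)s3)n2)cc(C)c1OC[C@@H](O)CNC(=O)CO` differs from compound 1 by 5-((dimethylamino)methyl)-4-methylthiophen-2-yl in place of 3-((ethyl(methyl)amino)methyl)-5-methylphenyl on an aromatic carbon. This change runs opposite to the measured steps, shortening the amine chain and shrinking the ring. A downward step a number 0.50 log units lower from compound 1 to compound 4 (beyond the scatter) in this assay is therefore expected, and compound 4 is estimated at 2.9, between 2.4 and 3.4.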

Compound 4, distribution coefficient: 3.2
The estimate for compound 4 lay 0.30 log units below the measured number, within the range that was stated.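

In this assay, replacing 3-((ethyl(methyl)amino)methyl)-5-methylphenyl with 5-((dimethylamino)methyl)-4-methylthiophen-2-yl gives a number 0.20 log units lower from compound 1 to compound 4 (within the scatter). Here, then, a change of both ring and amine group, with fewer heavy atoms, stays within the scatter, whereas the earlier carbon additions to the amine chain gave steps beyond it. Nothing shown gives a cause for this result.

As far as these compounds go, because ring and amine changed together, their separate contributions remain open. The same thiophene carrying an ethyl(methyl)amino group, or a morpholine, would begin to separate them.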